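Series notes: 3,4-dichlorophenyl in place of 4-aminophenyl

The source may report more compounds than this note shows. Statements on the series, on what has been measured and on what is new or still open speak of the compounds shown alone.

Compound 1 `COc1ccc(-c2cc(/C=C/C(=O)c3ccc(N)cc3)[nH]n2)cc1` and compound 2 `COc1cc(-c2cc(/C=C/C(=O)c3ccc(N)cc3)[nH]n2)cc(OC)c1OC` share the same core. In a functional assay on ACHN cells (Homo sapiens) for inhibition, read by sulforhodamine B assay, with a stated time of 48 h (a lower number here means a stronger inhibitor of growth, a higher number a weaker inhibitor of growth), compound 1 gives 2010 nM and compound 2 gives 1610 nM. Compound 2 holds the lower of the two numbers, but its gap to compound 1 lies within the scatter, so the two are not ordered. Compound 3 `COc1cc(-c2cc(/C=C/C(=O)c3ccc(Cl)c(Cl)c3)[nH]n2)cc(OC)c1OC` differs from compound 2 by 3,4-dichlorophenyl in place of 4-aminophenyl on a carbonyl carbon. Among the compounds with values here, no measured pair changes this carbonyl-attached group, so no step size is established; a step within the scatter, in either direction, is expected. Compound 3 is therefore expected at 1500 nM, with a range of 400 nM to 6000 nM. The expected step is a 1.1-fold lower number from compound 2 to compound 3 (0.03 log units; within the scatter).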

Compound 3, concentration for 50% growth inhibition: 21400 nM
For compound 3 the middle estimate is 14-fold (1.15 log units) below the measured one, outside the stated range (above it).
By their numbers in this assay, from the lowest: compounds 2 and 1 (each within the scatter of the next); then compound 3.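

The group on the carbonyl carbon matters for growth inhibition: in this assay, 3,4-dichlorophenyl in place of 4-aminophenyl gives a 13-fold higher number from compound 2 to compound 3 (1.12 log units; beyond the scatter). Within the data shown here, this is the first measured change at this position, since compound 1 and compound 2 share the 4-aminophenyl group and say nothing about it. No evidence on the cause of this step is available.

As far as these compounds go, it remains open whether losing the amine or adding the chlorines drives the step; an unsubstituted phenyl group on the carbonyl carbon would help separate the two. From the compounds shown here alone, whether the step carries over to the core of compound 1 is also open.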